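The compounds below may be only part of what the source reports. "The series", "measured", "known", "first", "only" and "open" are said of these compounds alone.

Two measured compounds share a common core. Compound 1 `O=C(Nc1nc2ccccc2s1)c1cn(-c2ccccc2)nc1-c1ccccc1` in a functional assay on PC-3 cells (Homo sapiens) for cytotoxicity, read by MTT assay, with a stated time of 72 h (on this read-out lower numbers stand for stronger inhibition and higher numbers for weaker inhibition), gives 10400 nM. Compound 2 `O=C(Nc1nc2ccccc2s1)c1cn(-c2ccccc2)nc1-c1ccc(Cl)cc1`, which carries a chloro group in place of a hydrogen on an aromatic carbon, gives in this assay 7750 nM. For the measured compounds named here, the step of a 1.3-fold lower number from compound 1 to compound 2 (0.13 log units; within the scatter) is the only measured step so far, and it places the two numbers within the ordinary scatter of each other, so compound 2 stands alongside compound 1 rather than apart from it. Compound 3 `COc1ccc2nc(NC(=O)c3cn(-c4ccccc4)nc3-c3ccc(Cl)cc3)sc2c1` differs from compound 2 by methoxy in place of hydrogen on an aromatic carbon. Going by the values given here, no measured step touches this position; the single step from compound 1 to compound 2 concerns a different ring and stayed within the scatter, so it offers no guide to the size or direction of a change here. With nothing to argue for a shift, compound 3 is expected to stay close to compound 2 in this assay. The step of a 1.1-fold lower number from compound 2 to compound 3 (0.04 log units; within the scatter) is estimated to lie within the scatter. The estimate for compound 3 is 7000 nM, with a range from 2500 nM to 20000 nM.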

Compound 3, half-maximal inhibitory concentration: 29300 nM
Estimate against measurement, compound 3: 4.2-fold (0.62 log units) below; the whole stated range lies below it.
By their numbers in this assay, from the lowest: compounds 2 and 1 (each within the scatter of the next); then compound 3.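

The step of a 3.8-fold higher number from compound 2 to compound 3 (0.58 log units; beyond the scatter) in this assay shows that this place, an aromatic carbon of a six-membered aromatic ring of carbon only, part of a fused or bridged system of two rings, is not indifferent to what it carries. Methoxy in place of hydrogen here moves the number beyond the scatter and toward weaker inhibition, whereas the earlier step of a 1.3-fold lower number from compound 1 to compound 2 (0.13 log units; within the scatter) on a different ring stayed within it, so the two places need not respond alike, though each is known from one change only. No measurement shown here gives a reason for this rise.

A single group at this place cannot tell whether any addition there raises the number or whether methoxy is special, and a hydroxyl group, a fluoro group, an amine or a longer chain such as ethoxy at the same carbon would help separate those readings. On these data alone, it also remains open whether methoxy has the same effect on the core of compound 1, which lacks the chloro group, or at the other carbons of this ring.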